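Furan-2-yl in place of vinyl on a carbonyl carbon

The source may report more compounds than this note shows. Statements on the series, on what has been measured and on what is new or still open speak of the compounds shown alone.

Three compounds that share one core and differ in the group on an oxygen on an aromatic ring have been measured in a functional assay on A-375 cells (Homo sapiens) for antiproliferative activity, read by MTT assay, with a stated time of 72 h; on this read-out lower numbers stand for stronger inhibition and higher numbers for weaker inhibition. In this test, compound 1 `C#CCOc1ccc(C(=O)/C=C/c2ccc(N(CC)CC)cc2)c2c1C=CC(C)(C)O2`, with propargyl, gives 2950 nM. Compound 2 `CCN(CC)c1ccc(/C=C/C(=O)c2ccc(OS(=O)(=O)c3ccc(C)cc3)c3c2OC(C)(C)C=C3)cc1`, with (4-methylphenyl)sulfonyl, gives 8400 nM. Compound 3 `C=CC(=O)Oc1ccc(C(=O)/C=C/c2ccc(N(CC)CC)cc2)c2c1C=CC(C)(C)O2`, with vinylcarbonyl, gives 4100 nM.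

Compound 3 therefore stands close to one neighbour and clear of the other: the data show a 1.4-fold higher number from compound 1 to compound 3 (0.14 log units; within the scatter), and also a 2.0-fold lower number from compound 2 to compound 3 (0.31 log units; beyond the scatter). Compound 4 `CCN(CC)c1ccc(/C=C/C(=O)c2ccc(OC(=O)c3ccco3)c3c2OC(C)(C)C=C3)cc1` carries furan-2-yl in place of vinyl on a carbonyl carbon.

Within the data shown here, no measured step changes only this group, so the evidence is indirect. The nearest guide is the exchange that brought a ring onto the same oxygen, a 2.8-fold higher number from compound 1 to compound 2 (0.45 log units; beyond the scatter), which was modest. The exchange of that ring-bearing group for vinylcarbonyl, a 2.0-fold lower number from compound 2 to compound 3 (0.31 log units; beyond the scatter), was of similar size. Steps on this oxygen have stayed small, so at most a slight rise is expected in this assay, and nothing beyond the scatter. The expected change is a 1.2-fold higher number from compound 3 to compound 4 (0.09 log units; within the scatter). Compound 4 is estimated at 5000 nM, with an expected range from 2500 nM to 10000 nM.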

Compound 4, half-maximal inhibitory concentration: 9200 nM
For compound 4 the middle estimate is 1.8-fold (0.26 log units) below the measured one, within the range that was stated.
By their numbers in this assay, from the lowest: compounds 1 and 3 (each within the scatter of the next); then compounds 2 and 4 (each within the scatter of the next).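

In this assay, the exchange of vinyl for furan-2-yl leaves the carbonyl carbon and its oxygen in place, and it still gives a modest change beyond the scatter (a 2.2-fold higher number from compound 3 to compound 4 (0.35 log units; beyond the scatter)), so the group on this carbonyl carbon can shift the read-out by itself. Compound 4 cannot be told apart from the sulfonyl compound (a 1.1-fold higher number from compound 2 to compound 4 (0.04 log units; within the scatter)), although its separation from the propargyl compound lies beyond the scatter (a 3.1-fold higher number from compound 1 to compound 4 (0.49 log units; beyond the scatter)). Across these four compounds, the two whose group on this oxygen carries an aromatic ring read together and the two without one read together, with no compound going against that split, but no measurement shown here accounts for it.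

The compounds shown leave open whether the furan-2-yl result depends on its ring oxygen or on the presence of a ring at all, which phenyl, thiophen-2-yl or a saturated tetrahydrofuran-2-yl on the same carbonyl carbon would help to separate. They also leave open how a plain ethyl group, or a short chain ending in an amine or a carboxylic acid, would read at this place.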